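The compounds below may be only part of what the source reports. "The series", "measured", "known", "first", "only" and "open" are said of these compounds alone.

Two compounds share one core and differ only in the group on one aromatic carbon. Compound 1 `Cc1cc(O)c(C(C)C)cc1-c1cc(-c2cccs2)c(C#N)c(=O)[nH]1` carries a thiophen-2-yl there, and in a functional assay for inhibition, tested at 60 ug/mL (a lower number here means a weaker effect, a higher number a stronger effect of the compound at the concentration tested), compound 1 gives 54.3%. Compound 2 `COc1ccc(-c2cc(-c3cc(C(C)C)c(O)cc3C)[nH]c(=O)c2C#N)c(OC)c1` carries a 2,4-dimethoxyphenyl instead, and in this assay compound 2 gives 48.5%. Of these two numbers that of compound 2 is the lower, yet the step of a number 5.8 percentage points lower from compound 1 to compound 2 (within the scatter) lies within the scatter, so the two compounds cannot be told apart on this evidence.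

Compound 3 `COc1cc(-c2cc(-c3cc(C(C)C)c(O)cc3C)[nH]c(=O)c2C#N)ccc1O` is not yet measured. The change from compound 2 is 4-hydroxy-3-methoxyphenyl in place of 2,4-dimethoxyphenyl on an aromatic carbon. Going by the values given here, the only step that bears on it is the one at the same position, from compound 1 to compound 2, which was within the scatter. No step beyond the scatter is therefore expected, and the estimated step is a number 0.5 percentage points lower from compound 2 to compound 3 (within the scatter). For compound 3 the estimated inhibition in this assay is 48%, with a range from 30% to 66%.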

Compound 3, a percentage reported as inhibition, at one concentration (the size of the read-out at that concentration, not a potency): 37.5%
Estimate against measurement, compound 3: 10.5 percentage points above; measured number inside the range.
By their numbers in this assay, from the lowest: compound 3; then compounds 2 and 1 (each within the scatter of the next).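

Replacing 2,4-dimethoxyphenyl with 4-hydroxy-3-methoxyphenyl shows that this position can respond to the group it carries: in this assay the change gives (a number 11 percentage points lower from compound 2 to compound 3 (beyond the scatter)), a step beyond the scatter, which the earlier pair did not show. Measured against thiophen-2-yl, the 4-hydroxy-3-methoxyphenyl group also gives a step beyond the scatter (a number 16.8 percentage points lower from compound 1 to compound 3 (beyond the scatter)). Compound 3 therefore stands apart from both earlier compounds, although those two cannot be told apart from each other.

Still open, going by these compounds, is which difference between the two phenyl groups goes with the lower number, the hydrogen-bond donor or the changed arrangement of oxygen groups, and what a phenyl ring bearing an amine or a carboxylic acid would give here. No independent measurement is available to explain the step.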